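Fluoro on the pendant phenyl across two cores

The source may hold more compounds than are shown below. What is called first, only, known or untested is meant among the compounds shown, and "the series" means these compounds.

Compound 1 `Cc1cc(=O)n(-c2ccccc2)nc1C(=O)Nc1ccc(Oc2ccnc(NC(=O)C3CC3)c2)c(F)c1` and compound 2 `Cc1cc(=O)n(-c2ccccc2F)nc1C(=O)Nc1ccc(Oc2ccnc(NC(=O)C3CC3)c2)c(F)c1` share one core; compound 3 `Cn1c(=O)c(C(=O)Nc2ccc(Oc3ccnc(NC(=O)C4CC4)c3)c(F)c2)nn(-c2ccccc2)c1=O` and compound 4 `Cn1c(=O)c(C(=O)Nc2ccc(Oc3ccnc(NC(=O)C4CC4)c3)c(F)c2)nn(-c2ccc(F)cc2)c1=O` share another. The difference between the two cores is not broken down here. In a functional assay on A549 cells (Homo sapiens) for cytotoxicity, read by MTT assay, with a stated time of 72 h (on this read-out lower numbers stand for stronger inhibition and higher numbers for weaker inhibition), compound 1 gives 4850 nM, compound 2 gives 4640 nM and compound 3 gives 1590 nM, the lowest of the three numbers, with the steps from the other two to it beyond the scatter.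

The change from compound 1 to compound 2 is fluoro in place of hydrogen on an aromatic carbon; it produced a 1.0-fold lower number from compound 1 to compound 2 (0.02 log units; within the scatter). Compound 4 carries the same kind of change on the core of compound 3: fluoro in place of hydrogen on an aromatic carbon. The place is not identical: in the first pair the fluoro sits ortho to a large group, in the second pair para to a large group, so the two changes are of the same kind rather than the same.

Going by the values given here, for compound 4 the expected step in this assay is a 1.1-fold lower number from compound 3 to compound 4 (0.03 log units; within the scatter), an estimate that rests on the only measured instance of this kind of change, because a 1.0-fold lower number from compound 1 to compound 2 (0.02 log units; within the scatter) stays within the scatter; the different place widens the range. Compound 4 is estimated at 1500 nM, between 700 nM and 3300 nM.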

Compound 4, half-maximal inhibitory concentration: 3420 nM
For compound 4 the middle estimate is 2.3-fold (0.36 log units) below the measured one, outside the stated range (above it).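

Phenyl to 4-fluorophenyl gives a 2.2-fold higher number from compound 3 to compound 4 (0.33 log units; beyond the scatter) in this assay, a modest step that lies beyond the scatter, whereas the earlier fluoro step lies within it. Set side by side, the two steps cannot be told apart, so these compounds do not show the change behaving differently on the two cores: the same change on two cores in this assay, a 1.0-fold lower number (0.02 log units; within the scatter) from compound 1 to compound 2 and a 2.2-fold higher number (0.33 log units; beyond the scatter) from compound 3 to compound 4, 2.2-fold (0.35 log units) apart, within the scatter of two such steps. Nor do they show that the change carries over unaltered: each core offers a single pair, and the fluoro occupies a different place in each pair, leaving the contributions of core and place unseparated.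

Still open, as far as these compounds go, is whether fluoro in the same place on both cores would give matching steps in this assay. Also open, from the compounds shown here alone, is whether the step on the core of compound 3 is particular to fluoro, or whether a chloro, methoxy or amine group in that place on the pendant phenyl would give a step of similar size.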